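The source may report more compounds than this note shows. Statements on the series, on what has been measured and on what is new or still open speak of the compounds shown alone.

Measured so far, in a functional assay on A549 cells (Homo sapiens) for antiproliferative activity, read by MTT assay, with a stated time of 72 h; a higher number here means a weaker inhibitor, a lower number a stronger inhibitor:

Compound 1 `CNC(=O)c1cc(Oc2ccc(NC(=O)c3cc4cccnc4n(-c4ccc(F)cc4)c3=O)cc2)ccn1`: 110 nM
Compound 2 `CNC(=O)c1cc(Oc2ccc(NC(=O)c3cc4cccnc4n(-c4ccc(C(F)(F)F)cc4Cl)c3=O)cc2)ccn1`: 2090 nM

Among these two numbers compound 2 has the higher one, so it is the weaker inhibitor; the only step measured is a 19-fold higher number from compound 1 to compound 2 (1.28 log units; beyond the scatter), a large change that follows from swapping the group on the aromatic nitrogen of the shared core.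

Compound 3 `CNC(=O)c1cc(Oc2ccc(NC(=O)c3cc4cccnc4n(-c4ccc(F)c(Cl)c4)c3=O)cc2)ccn1` is not yet measured. It differs from compound 2 in that same place: 3-chloro-4-fluorophenyl in place of 2-chloro-4-(trifluoromethyl)phenyl on an aromatic nitrogen. Within the data shown here, the only step that bears on this change is the one from compound 1 to compound 2, which shows that a 4-fluorophenyl on this nitrogen gave a much lower number than a 2-chloro-4-(trifluoromethyl)phenyl. The group entering in compound 3 keeps the fluorine of compound 1 and adds one chlorine, while the trifluoromethyl and the other chlorine of compound 2 leave. The expectation is therefore a step back toward the number of compound 1, of size a 9.5-fold lower number from compound 2 to compound 3 (0.98 log units; beyond the scatter), that is a lower number and a stronger inhibitor than compound 2. Compound 3 is estimated at 220 nM, with a range from 60 nM to 800 nM.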

Compound 3, half-maximal inhibitory concentration: 1560 nM
Compound 3: the middle estimate sits 7.1-fold (0.85 log units) below what was measured; measured number above the stated range.
By their numbers in this assay, from the lowest: compound 1; then compounds 3 and 2 (each within the scatter of the next).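

In this assay, 3-chloro-4-fluorophenyl in place of 2-chloro-4-(trifluoromethyl)phenyl on the aromatic nitrogen gives a 1.3-fold lower number from compound 2 to compound 3 (0.13 log units; within the scatter), so these two differently substituted rings cannot be told apart here, even though the trifluoromethyl group is gone from compound 3. The large step between compound 1 and compound 2 therefore does not depend on trifluoromethyl: adding a single chloro to the 4-fluorophenyl ring of compound 1 gives a 14-fold higher number from compound 1 to compound 3 (1.15 log units; beyond the scatter), and among these three compounds the two with a chlorine on this ring both have much higher numbers than the one without, with none going against that pattern. No measurement available here gives a reason for this sensitivity to one chlorine.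

The compounds shown leave open whether chlorine itself matters or whether another small group on this ring, such as methyl or methoxy, would give a similar number. They also leave open how a 4-(trifluoromethyl)phenyl with no chlorine, or a plain phenyl, would compare with the 4-fluorophenyl of compound 1.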